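The source may report more compounds than this note shows. Statements on the series, on what has been measured and on what is new or still open speak of the compounds shown alone.

Of the compounds shown here, two have numbers so far in a functional assay on A549 cells (Homo sapiens) for antiproliferative activity, read by MTT assay, with a stated time of 48 h; a lower number here means a stronger inhibitor, a higher number a weaker inhibitor. Compound 1 `Cc1ccc(-c2cc(NC(=O)/C=C/c3ccc(Cl)cc3)n[nH]2)cc1` gives 1490 nM and compound 2 `Cc1ccc(-c2cc(NC(=O)/C=C/c3ccc(C(F)(F)F)cc3)n[nH]2)cc1` gives 1020 nM. These two values lie within the scatter of each other, so compound 2 cannot be separated from compound 1 on the present numbers.

The next compound is compound 3 `Cc1ccc(-c2cc(NC(=O)/C=C/c3ccc(F)cc3)n[nH]2)cc1`. It keeps the shared core and differs from compound 2 by fluoro in place of trifluoromethyl on an aromatic carbon, para to a large group (fluoro in place of trifluoromethyl on an aromatic carbon).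

Among the compounds with values here, only one measured step bears on this change: the replacement of chloro by trifluoromethyl at the same place, a 1.5-fold lower number from compound 1 to compound 2 (0.16 log units; within the scatter). Within the data shown here, no compound with fluoro at this place has a number yet, so that step is a limited guide. Since a 1.5-fold lower number from compound 1 to compound 2 (0.16 log units; within the scatter) stayed within the scatter, no step beyond the scatter is expected for compound 3 in this assay.

The expected step is a 1.4-fold higher number from compound 2 to compound 3 (0.14 log units; within the scatter), which would not be distinguishable from the scatter. For compound 3 the estimate is 1400 nM, with an expected range of 600 nM to 3200 nM.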

Compound 3, half-maximal inhibitory concentration: 1250 nM
Compound 3: middle estimate off by 1.1-fold (0.05 log units), on the high side; the measured number falls inside the stated range.
By their numbers in this assay, from the lowest: compounds 2, 3 and 1 (each within the scatter of the next).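

In this assay fluoro in place of trifluoromethyl gives a 1.2-fold higher number from compound 2 to compound 3 (0.09 log units; within the scatter) on the aromatic carbon para to a large group, while fluoro in place of chloro at the same place gives a 1.2-fold lower number from compound 1 to compound 3 (0.08 log units; within the scatter) in the same assay. With a third group now at this place, compounds 1, 2 and 3 still cannot be separated, and this holds even for the change from trifluoromethyl with 4 heavy atoms to fluoro with 1 heavy atom, so the number has so far shown no readable response to the exchange of these three groups. No measurement is at hand that would account for this flat result.

Still open, as far as these compounds go, is whether any group at this place can move the number beyond the scatter, for example an amine, a hydroxyl, a carboxylic acid or a longer chain such as butyl. Also open, from the compounds shown here alone, is whether a change elsewhere on the shared core, away from this place, would give a step that can be told apart from the scatter at all.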